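Removing the Amino Group from Compound 1

This account rests on a few compounds, and the source may have more. Where it says the series, first, only, none or still open, it means among the compounds named here.

Compound 1 `Nc1nc(Cl)c2ncn(Cc3ccccc3CCl)c2n1` was tested in a functional assay on DU-145 cells (Homo sapiens) for cytotoxicity, read by sulforhodamine B assay, with a stated time of 48 h (a higher number here means a weaker inhibitor of growth, a lower number a stronger inhibitor of growth), and compound 1 gives 32400 nM. Compound 3 `ClCc1ccc(Cn2cnc3c(Cl)nc(Cl)nc32)cc1` gives 17800 nM in this assay, a number within the scatter of that of compound 1, so the two cannot be told apart. Compound 2 `ClCc1cccc(Cn2cnc3nc(Cl)nc(Cl)c32)c1` gives 260 nM, a number far lower and beyond the scatter. Compound 4 `ClCc1ccccc1Cn1cnc2c(Cl)ncnc21` has not yet been measured in this assay. It differs from compound 1 in one place: hydrogen in place of amino on an aromatic carbon. No single change of this kind between measured compounds is available, so the size of the step is open. Compound 4 is expected to give 15000 nM in this assay, within a range from 3000 nM to 60000 nM, an expected step of a 2.2-fold lower number from compound 1 to compound 4 (0.33 log units; beyond the scatter) that may not exceed the scatter.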

Compound 4, concentration for total growth inhibition: 34700 nM
Beside the measured number, compound 4's estimate is 2.3-fold (0.36 log units) below it, and the stated range covers the measured number.
By their numbers in this assay, from the lowest: compound 2; then compounds 3, 1 and 4 (each within the scatter of the next).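

Putting hydrogen in place of amino on this aromatic carbon, between two ring nitrogen atoms, gives a 1.1-fold higher number from compound 1 to compound 4 (0.03 log units; within the scatter) in this assay. For the compounds shown here, this is the first single change read, and it shows that the amino group at this position can be lost with no difference this assay can tell. Nothing shown here gives a reason for this result.

From the compounds shown here alone, what a methoxy group, a dimethylamino group or a carboxylic acid on this carbon would do remains open. The compounds shown also offer no single change elsewhere on the core.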